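Cyclopropyl to Methyl Next to the Ring Nitrogen

A few compounds are considered here, and "the series" means these few. Any claim that something is new, unique, unknown or untested is made for them only; others in the source may bear on it.

Of the compounds shown here, three built on a shared core have been tested in an ADME assay on HCT-116 cells (Homo sapiens) for cytotoxicity, read by CellTiter-Glo, with a stated time of 72 h; on this read-out higher numbers stand for weaker inhibition and lower numbers for stronger inhibition. Compound 1 `CC1CCN(C2CCN(S(=O)(=O)c3cccc(Br)c3)CC2)CC1` gives > 5000 nM in this assay, which is a limit of the assay rather than a number. Compound 2 `CC1CCN(C2CCN(S(=O)(=O)c3cn(C)cn3)CC2)CC1` gives > 10000 nM in this assay, again a limit. The step that the two limits leave unreadable from compound 1 to compound 2 is consequently unreadable. Compound 3 `CC1CCN(C2CCN(S(=O)(=O)c3sc(Cl)nc3C3CC3)CC2)CC1` gives > 10000 nM in this assay, likewise a limit. Among the compounds with values here, compound 3 thus stands at the limit at which most of the values sit (the limit of > 10000 nM in this assay, at which 2 of the 3 values shown sit), and the one remaining value is itself a limit (the limit of > 5000 nM in this assay, at which 1 of the 3 values shown sits), so nothing among the three compounds can be placed in order.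

Compound 4 `Cc1nc(Cl)sc1S(=O)(=O)N1CCC(N2CCC(C)CC2)CC1` differs from compound 3 in one place: methyl in place of cyclopropyl on an aromatic carbon. The change sits on an aromatic carbon of a five-membered aromatic ring with one nitrogen and one sulfur, next to the ring nitrogen and two ring bonds from the ring atom that bears a chloro group. Within the data shown here, no measured step is readable, so none bears on this change; the only pair that differs in one place, compound 1 and compound 2, is hidden by two limits. Compound 4 is therefore expected to stay at the limit, with an estimated 15000 nM and a range from 5000 nM to 50000 nM. The step that the limit leaves unreadable from compound 3 to compound 4 is expected to be none beyond the scatter.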

Compound 4, half-maximal inhibitory concentration: > 10000 nM
Compound 4 was reported as a limit; the forecaster's own chance of this, stated with the estimate: 90%; the middle value is on the limit's open side.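

In this assay compound 4 gives > 10000 nM, which is a limit of the assay. As compound 1, compound 2 and compound 3 are also reported as limits, no step between any of these compounds can be read. The compounds shown leave open whether methyl in place of cyclopropyl on an aromatic carbon changes the read-out at all, and what actual value any of the four compounds would have.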